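One Added Methyl on the Side Chain of Compound 3

The compounds below may be only part of what the source reports. "The series", "measured", "known", "first", "only" and "open" are said of these compounds alone.

In a functional assay on DU-145 cells (Homo sapiens) for cytotoxicity, read by MTT assay (a higher number here means a weaker inhibitor, a lower number a stronger inhibitor), compound 3 `CC(C)=CC[C@@H](OC(=O)CC(O)c1ccccc1)C1=CC(=O)c2c(O)ccc(O)c2C1=O` gives 17000 nM, within the scatter of compound 1 `CC(C)=CC[C@@H](OC[C@H](C)O)C1=CC(=O)c2c(O)ccc(O)c2C1=O` at 24500 nM. Compound 2 `CC(C)=CC[C@@H](OC(=O)c1ccco1)C1=CC(=O)c2c(O)ccc(O)c2C1=O` reads > 100000 nM, which is a limit of the assay and not a number (the limit of > 100000 nM in this assay, at which 1 of the 3 values shown sits). Compound 4 `CC(C)=CC[C@@H](OC(=O)CC(C)(O)c1ccccc1)C1=CC(=O)c2c(O)ccc(O)c2C1=O` has methyl in place of hydrogen on a saturated chain carbon, turning 2-hydroxy-2-phenylethyl into 2-hydroxy-2-phenylpropyl (methyl in place of hydrogen on a saturated chain carbon bound to an aromatic carbon, an oxygen on a saturated carbon and a saturated chain carbon). Two measured steps changed this part of the molecule: an at least 4.0-fold higher number from compound 1 to compound 2 (0.61 log units; beyond the scatter), and an at least 5.8-fold lower number from compound 2 to compound 3 (0.76 log units; beyond the scatter). Both exchanged whole groups, and neither tests a single methyl, so they offer only a loose guide. The expected change is therefore no larger than the scatter: a 1.1-fold higher number from compound 3 to compound 4 (0.02 log units; within the scatter). Compound 4 is estimated at 18000 nM, with an expected range of 7000 nM to 45000 nM.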

Compound 4, half-maximal inhibitory concentration: > 100000 nM
Compound 4 gave a limit, no number; the forecaster's own chance of this, stated with the estimate: 7%; middle value at least 5.5-fold (0.74 log units) away from the limit.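

In this assay compound 4 reads > 100000 nM, which is a limit of the assay and not a number: the limit of > 100000 nM in this assay, at which 2 of the 4 values shown sit. Even so, a single methyl in place of hydrogen on this saturated chain carbon gives an at least 5.8-fold higher number from compound 3 to compound 4 (0.76 log units; beyond the scatter), so one added carbon here matters, which the earlier whole-group exchanges could not show. The step from compound 2 to compound 4 cannot be read.

On these data alone, how an ethyl or a fluorine in place of that hydrogen would read remains open. So does the true value of compound 4, and whether any cytotoxicity remains.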